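Indolyl Oxadiazole Amines: From Aryl to Benzyl on Nitrogen

The source may report more compounds than this note shows. Statements on the series, on what has been measured and on what is new or still open speak of the compounds shown alone.

In a functional assay on MDA-MB-231 cells (Homo sapiens) for inhibition, read by MTT assay, with a stated time of 72 h (on this read-out lower numbers stand for stronger inhibition and higher numbers for weaker inhibition), the compounds stand as follows:
- Compound 1 `Fc1ccc(Nc2nnc(-c3c[nH]c4ccccc34)o2)cc1` gives > 100000 nM (a limit of the assay)
- Compound 2 `Cc1ccc(Nc2nnc(-c3c[nH]c4ccccc34)o2)cc1` gives 27300 nM
- Compound 3 `c1ccc(CNc2nnc(-c3c[nH]c4ccccc34)o2)cc1` has not yet been measured

Among the measured compounds shown here, compound 2 holds the only actual number in this small series. Compound 1 offers only a limit (the limit of > 100000 nM in this assay, at which 1 of the 2 values shown sits). The next change is benzyl in place of 4-methylphenyl on a nitrogen on an aromatic ring. For the measured compounds named here, only one measured step bears on it, an at least 3.6-fold lower number from compound 1 to compound 2 (0.56 log units; beyond the scatter) (methyl in place of fluoro on an aromatic carbon). That step shows that this assay responds to a change within the group on this nitrogen. Going by the values given here, no measured step replaces the whole group, so neither size nor direction can be carried over. No step beyond the scatter is therefore expected, though with wide uncertainty. The estimated step is a 1.1-fold higher number from compound 2 to compound 3 (0.04 log units; within the scatter) in this assay and could still fall either way. For compound 3 the estimate is 30000 nM with an expected range from 8000 nM to 100000 nM as its bounds.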

Compound 3, half-maximal inhibitory concentration: 6470 nM
Compound 3: the middle estimate sits 4.6-fold (0.67 log units) above what was measured; the measured number lies below the stated range.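

In this assay, replacing the whole group on this nitrogen, with the same atoms joined differently, gives a 4.2-fold lower number from compound 2 to compound 3 (0.63 log units; beyond the scatter), so the read-out responds to how the aromatic ring is attached to the nitrogen and not only to a change within the 4-substituted phenyl group. The benzyl group also gives an at least 15-fold lower number from compound 1 to compound 3 (1.18 log units; beyond the scatter), a second comparison that points the same way. Compound 1 is a limit and not a number, so that step has no upper end: the limit of > 100000 nM in this assay, at which 1 of the 3 values shown sits.

The compounds shown leave open whether the lower number belongs to benzyl alone or would persist with a longer chain such as phenethyl. They also do not tell what a fluoro or methyl group on the benzyl ring, or an amine or carboxylic acid there, would do in this assay.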